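A few compounds are considered here, and "the series" means these few. Any claim that something is new, unique, unknown or untested is made for them only; others in the source may bear on it.

Compound 1 `Cc1cc(NC(=O)Nc2ccc(F)cc2)c2ccccc2n1` gives > 25000 nM in an ADME assay on BJ cells (Homo sapiens) for cytotoxicity, with a stated time of 72 h (on this read-out higher numbers stand for an effect only at larger amounts of compound and lower numbers for an effect already at smaller amounts), which is a limit of the assay.
Compound 2 `Cc1cc(NC(=O)Nc2ccc(Cl)cc2)c2ccccc2n1` gives > 25000 nM in this assay, again a limit.
Compound 3 `Cc1cc(NC(=O)Nc2ccccc2OC(F)(F)F)c2ccccc2n1` gives > 25000 nM in this assay, also a limit.

Compound 3 therefore stands at the limit, together with the other two measured compounds; all three values sit at the limit of > 25000 nM in this assay, at which 3 of the 3 values shown sit. The step from compound 1 to compound 2, a step that the two limits leave unreadable from compound 1 to compound 2, cannot be read because both ends are limits.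

Compound 4 `COc1ccccc1NC(=O)Nc1cc(C)nc2ccccc12` differs from compound 3 by methyl in place of trifluoromethyl on an oxygen on an aromatic ring. Among the compounds with values here, no measured step bears directly on this change. Within the data shown here, the one measured step, between two limits, gives no size in either direction, and every value shown is itself a limit. On that basis no step beyond the scatter is expected from compound 3 to compound 4 in this assay, and the expected step is a step that the limit leaves unreadable from compound 3 to compound 4. Compound 4 is expected to give about 30000 nM in this assay, with a range from 12000 nM to 80000 nM, and most probably only a limit will again be reported.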

Compound 4, half-maximal effective concentration: > 25000 nM
Compound 4 was reported as a limit; the forecaster's own chance of this, stated with the estimate: 85%; the middle value lies beyond the limit too.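

Compound 3 and compound 4 both stand at a limit, so no step between them can be read: the limit of > 25000 nM in this assay, at which 4 of the 4 values shown sit.

The compounds shown leave open at what amount any of the four would show an effect in this assay, and whether any change among them alters the read-out.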